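Swapping the Thiophene for a Pyrazole in Compound 1

A few compounds are considered here, and "the series" means these few. Any claim that something is new, unique, unknown or untested is made for them only; others in the source may bear on it.

Measured compounds:
compound 1 `CCN(Cc1cccs1)C(=O)COc1ccc(C)cc1`, 8 nM
compound 2 `Cc1ccc(OCC(=O)N(Cc2cccs2)CC(C)C)cc1`, 900 nM
compound 3 `Cc1ccc(OCC(=O)N(Cc2cccs2)c2cnn(C)c2)cc1`, 63000 nM

In an assay on HEK293 cells for agonist activity at transient receptor potential cation channel subfamily M member 8 (Homo sapiens), read by fluorescence and calcium flux, with a stated time of 15 min (a lower number here means that less compound is needed, a higher number that more compound is needed for the effect), compound 1 has the lowest number of the three, its nearest neighbour being reached by a 110-fold higher number from compound 1 to compound 2 (2.05 log units; beyond the scatter) and the furthest by a 7900-fold higher number from compound 1 to compound 3 (3.90 log units; beyond the scatter). The step to compound 4 `CCN(Cc1cn[nH]c1)C(=O)COc1ccc(C)cc1` is 1H-pyrazol-4-yl in place of thiophen-2-yl on a saturated chain carbon bound to an amide-type nitrogen. Within the data shown here, no measured step touches this position: the changes to compound 2 and compound 3 (a 70-fold higher number from compound 2 to compound 3 (1.85 log units; beyond the scatter)) all alter the other group on the amide-type nitrogen. Going by these compounds, each of those changes raised the number by a large amount, so the shared core appears sensitive to substitution at that nitrogen, but the present change is untested. Compound 4 is therefore expected at 120 nM, within 10 nM to 2500 nM, meaning an expected 15-fold higher number from compound 1 to compound 4 (1.18 log units; beyond the scatter).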

Compound 4, half-maximal effective concentration: "active" (no number reported)
For compound 4 the study gives words and no number, so the estimate cannot be set against anything.
By their numbers in this assay, from the lowest: compound 1; then compound 2; then compound 3.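

Among these compounds, compound 4 is reported only as active, without a number, so in this assay no step from compound 1 to compound 4 can be read. The compounds shown leave open how far 1H-pyrazol-4-yl in place of thiophen-2-yl moves the number. No supporting evidence bears on this result.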